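The source may report more compounds than this note shows. Statements on the series, on what has been measured and on what is new or still open speak of the compounds shown alone.

In an ADME assay on Vero cells (Chlorocebus sabaeus) for cytotoxicity, read by CellTiter-Glo, with a stated time of 72 h (a lower number here means that less compound is tolerated, a higher number that more compound is tolerated), compound 1 (`[O-][n+]1nc(NC2CC2)[n+]([O-])c2ccccc21`) gives 21 ug/mL, while compound 2 (`[O-][n+]1nc(N[C@@H]2C[C@H]3CC[C@@H]2C3)[n+]([O-])c2ccccc21`) gives 3.4 ug/mL. Compound 2 therefore holds the lower of the two numbers, and the gap lies beyond the usual scatter. Compound 3 (`[O-][n+]1nc(N[C@@H]2C[C@H]3CC[C@@H]2C3)[n+]([O-])c2ccc(Br)cc21`) differs from compound 2 by one change, bromo in place of hydrogen on an aromatic carbon. Within the data shown here, no measured pair shows this change, so the expectation in this assay is tentative: a small downward move, probably within the scatter. The expected step is a 1.4-fold lower number from compound 2 to compound 3 (0.13 log units; within the scatter). For compound 3 the estimated value is 2.5 ug/mL, with an expected range of 0.9 ug/mL to 7 ug/mL.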

Compound 3, half-maximal cytotoxic concentration: 0.8 ug/mL
The estimate for compound 3 lay 3.1-fold (0.49 log units) above the measured number; measured number outside the range, below it.
By their numbers in this assay, from the lowest: compound 3; then compound 2; then compound 1.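

In this assay, bromo in place of hydrogen on an aromatic carbon gives a 4.3-fold lower number from compound 2 to compound 3 (0.63 log units; beyond the scatter). Among these compounds, the earlier compounds carried only hydrogen there, so this is the first sign that a single substituent at this position of the shared core can move the tolerated concentration beyond the scatter. No evidence on hand accounts for the step.

As far as these compounds go, whether chloro, methoxy or an amine on the same carbon would move the number in the same direction stays open. So does whether bromo would give a similar step on compound 1.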